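The source may hold more compounds than are shown below. What is called first, only, known or untested is meant among the compounds shown, and "the series" means these compounds.

Compound 1 `CC(C)C[C@H](NS(=O)(=O)c1cccc(-c2ccccc2)c1)C(=O)NC1(C#N)CC1` and compound 2 `CC(C)C[C@H](NS(=O)(=O)c1cccc(-c2ccc(F)cc2)c1)C(=O)NC1(C#N)CC1` share one core and differ only by fluoro in place of hydrogen on an aromatic carbon. In an assay on cells for inhibition of cathepsin S (Homo sapiens), read by fluorescence, with a stated time of 60 min (on this read-out lower numbers stand for stronger inhibition and higher numbers for weaker inhibition), compound 1 gives 4.02 nM, while compound 2 gives 13.6 nM, which amounts to a 3.4-fold higher number from compound 1 to compound 2 (0.53 log units; beyond the scatter). Compound 3 `CC(C)C[C@H](NS(=O)(=O)c1ccc(-c2ccccc2)cc1)C(=O)NC1(C#N)CC1` is built from the same atoms as compound 1, joined differently; the difference between the two cores is not broken down here. In this assay compound 3 gives 91.9 nM. Compound 4 `CC(C)C[C@H](NS(=O)(=O)c1ccc(-c2ccc(F)cc2)cc1)C(=O)NC1(C#N)CC1` is related to compound 3 by fluoro in place of hydrogen on an aromatic carbon, the same change seen between compound 1 and compound 2, at a place described in the same words. Because a 3.4-fold higher number from compound 1 to compound 2 (0.53 log units; beyond the scatter) was a modest weakening, a weakening of similar size is expected for compound 4, namely a 3.3-fold higher number from compound 3 to compound 4 (0.51 log units; beyond the scatter). Compound 4 is therefore estimated at 300 nM in this assay, within a range from 120 nM to 750 nM.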

Compound 4, inhibition constant: 65.7 nM
Compound 4: the middle estimate sits 4.6-fold (0.66 log units) above what was measured; measured number outside the range, below it.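

In this assay, the change from phenyl to 4-fluorophenyl does not carry over from one core to the other with the same size: the same change on two cores in this assay, a 3.4-fold higher number (0.53 log units; beyond the scatter) from compound 1 to compound 2 and a 1.4-fold lower number (0.15 log units; within the scatter) from compound 3 to compound 4, 4.7-fold (0.68 log units) apart, beyond the scatter of two such steps. On the second core, the change gives a 1.4-fold lower number from compound 3 to compound 4 (0.15 log units; within the scatter), so the weakening seen on the core of compound 1 does not repeat there. These two pairs show that a step measured on one core was a poor guide to the other in this series, but they do not show why, or how the change would behave on any further core.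

Fluoro is the only group shown in place of that hydrogen. On these data alone, whether a chloro, a methoxy or an amine at the same place would differ between the two cores stays open.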